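The source may report more compounds than this note shows. Statements on the series, on what has been measured and on what is new or still open speak of the compounds shown alone.

Compound 1 `O=C(CSc1nnc(-c2ccncc2)o1)N/N=C/c1ccc(Cl)cc1` gives 15700 nM in a functional assay on HepG2 cells (Homo sapiens) for cytotoxicity, read by MTT assay, with a stated time of 48 h; on this read-out higher numbers stand for weaker inhibition and lower numbers for stronger inhibition.
Compound 2 `O=C(CSc1nnc(-c2ccncc2)o1)N/N=C/c1ccc(Br)cc1` gives 18600 nM in this assay.
Compound 3 `Cc1ccc(/C=N/NC(=O)CSc2nnc(-c3ccncc3)o2)cc1` gives 10000 nM in this assay.

All three compounds share the same core and differ only in one group on the aromatic ring. Compound 3 sits at the low end of the three numbers, but the steps of a 1.6-fold lower number from compound 1 to compound 3 (0.20 log units; within the scatter) and a 1.9-fold lower number from compound 2 to compound 3 (0.27 log units; within the scatter) are both within the scatter, as is a 1.2-fold higher number from compound 1 to compound 2 (0.07 log units; within the scatter), so nothing separates these compounds with confidence. Compound 4 `O=C(CSc1nnc(-c2ccncc2)o1)N/N=C/c1cc(Cl)ccc1O` carries 5-chloro-2-hydroxyphenyl in place of 4-methylphenyl on a carbon with a double bond to nitrogen. Going by the values given here, no measured step involves a hydroxyl group, so the closest guidance is that swapping groups on this ring has so far moved nothing beyond the scatter. Compound 4 is therefore expected to give 12000 nM, between 5000 nM and 30000 nM, a step of a 1.2-fold higher number from compound 3 to compound 4 (0.08 log units; within the scatter) that is not expected to exceed the scatter.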

Compound 4, half-maximal inhibitory concentration: 3970 nM
Compound 4: the middle estimate sits 3.0-fold (0.48 log units) above what was measured; the whole stated range lies above it.
By their numbers in this assay, from the lowest: compound 4; then compounds 3, 1 and 2 (each within the scatter of the next).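

Compound 4 shows that a change at this position can move the number beyond the scatter in this assay: the step to 5-chloro-2-hydroxyphenyl gives a 2.5-fold lower number from compound 3 to compound 4 (0.40 log units; beyond the scatter) and a 4.0-fold lower number from compound 1 to compound 4 (0.60 log units; beyond the scatter) and a 4.7-fold lower number from compound 2 to compound 4 (0.67 log units; beyond the scatter) and so makes compound 4 the strongest inhibitor of the four. The entering group differs from the earlier ones in carrying both a hydroxyl and a chlorine in one change, so these steps cannot assign the shift to either. No measured evidence accounts for this shift.

On these data alone, it remains open whether the hydroxyl without the chlorine would give a similar step. A methoxy group or an amine in the hydroxyl's place also remains untested among the compounds shown.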